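A few compounds are considered here, and "the series" means these few. Any claim that something is new, unique, unknown or untested is made for them only; others in the source may bear on it.

Measured compounds:
compound 1, `Cc1cccc(-n2c(C)cc(C(=O)O)c2C)c1`, in an assay on cells for inhibition of Palmitoleoyl-protein carboxylesterase NOTUM variant C330S (Homo sapiens), read by fluorescence, with a stated time of 40 min; on this read-out lower numbers stand for stronger inhibition and higher numbers for weaker inhibition: 1500 nM
compound 2, `Cc1cc(C(=O)O)c(C)n1-c1cccc(Cl)c1`, in this assay: 430 nM
compound 3, `Cc1cc(C(=O)O)c(C)n1-c1cccc(C2CC2)c1`, in this assay: 580 nM

Compound 3 holds the second highest of the three numbers. Its nearest neighbour is compound 2, and the step of a 1.3-fold higher number from compound 2 to compound 3 (0.13 log units; within the scatter) stays within the scatter; the furthest is compound 1, from which the step of a 2.6-fold lower number from compound 1 to compound 3 (0.41 log units; beyond the scatter) reaches beyond it. Compound 4, `Cc1cc(C(=O)O)c(C)n1-c1cccc(C(C)(C)C)c1`, differs from compound 3 by tert-butyl in place of cyclopropyl on an aromatic carbon. Among the measured compounds shown here, the steps that bear on this are the exchanges at the same place: a 3.5-fold lower number from compound 1 to compound 2 (0.54 log units; beyond the scatter), a 2.6-fold lower number from compound 1 to compound 3 (0.41 log units; beyond the scatter) and a 1.3-fold higher number from compound 2 to compound 3 (0.13 log units; within the scatter), the two non-methyl groups giving numbers within the scatter of each other. A step of no more than the scatter is therefore expected in this assay for compound 4, that is a 1.2-fold higher number from compound 3 to compound 4 (0.08 log units; within the scatter). Compound 4 is estimated at 700 nM, in the range 250 nM to 2000 nM.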

Compound 4, half-maximal inhibitory concentration: 460 nM
Estimate against measurement, compound 4: 1.5-fold (0.18 log units) above, and the stated range covers the measured number.
By their numbers in this assay, from the lowest: compounds 2, 4 and 3 (each within the scatter of the next); then compound 1.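

In this assay (this assay), tert-butyl at this place, a group with no ring, stays level with both cyclopropyl (a 1.3-fold lower number from compound 3 to compound 4 (0.10 log units; within the scatter)) and chloro (a 1.1-fold higher number from compound 2 to compound 4 (0.03 log units; within the scatter)). Methyl alone stands apart (a 3.3-fold lower number from compound 1 to compound 4 (0.51 log units; beyond the scatter)), so among these compounds a ring in the group is not needed for the lower number. No measurement here gives a reason for this.

The compounds shown leave open whether methoxy, an amine or a phenyl at this place would keep the numbers of chloro, cyclopropyl and tert-butyl. They also leave open how hydrogen there would compare.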